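Extending the chain of compound 3 by two carbons

A few compounds are considered here, and "the series" means these few. Any claim that something is new, unique, unknown or untested is made for them only; others in the source may bear on it.

Three compounds share a core that carries an acetylated amine, a chloromethyl ketone and a sulfur-linked saturated chain, and differ only in how far that chain reaches. Compound 1 `CCCCCCCSC[C@H](NC(C)=O)C(=O)CCl` gives 4800 nM in a functional assay on NALM-6 cells (Homo sapiens); a lower number here means a stronger inhibitor, a higher number a weaker inhibitor. Compound 2 `CCCCCCCCCSC[C@H](NC(C)=O)C(=O)CCl` gives 7300 nM in this assay. Compound 3 `CCCCCCCCCCSC[C@H](NC(C)=O)C(=O)CCl` gives 4700 nM in this assay, the lowest of the three numbers, though within the scatter of both others.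

Compound 4 `CCCCCCCCCCCCSC[C@H](NC(C)=O)C(=O)CCl` has not yet been measured. It differs from compound 3 by ethyl in place of hydrogen on a saturated chain carbon, ten or more bonds along the chain from a sulfur. The steps already seen all lengthen this same chain: a 1.5-fold higher number from compound 1 to compound 2 (0.18 log units; within the scatter), a 1.0-fold lower number from compound 1 to compound 3 (0.01 log units; within the scatter) and a 1.6-fold lower number from compound 2 to compound 3 (0.19 log units; within the scatter). None of these moved the number beyond the scatter, whether the chain grew by one, two or three carbons. Growing the chain by two more carbons is therefore expected to leave the number where it is, with a step of a 1.1-fold higher number from compound 3 to compound 4 (0.03 log units; within the scatter) that stays within the scatter. For compound 4 the expected value in this assay is 5000 nM, estimated to lie between 2000 nM and 12000 nM.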

Compound 4, half-maximal inhibitory concentration: 2000 nM
Compound 4: middle estimate off by 2.5-fold (0.40 log units), on the high side; the measured number falls inside the stated range.
By their numbers in this assay, from the lowest: compound 4; then compounds 3, 1 and 2 (each within the scatter of the next).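

In this assay, among the compounds shown here, lengthening the chain moves the number beyond the scatter for the first time, and the step can be read from each shorter compound (a 2.4-fold lower number from compound 3 to compound 4 (0.37 log units; beyond the scatter); a 3.7-fold lower number from compound 2 to compound 4 (0.56 log units; beyond the scatter); a 2.4-fold lower number from compound 1 to compound 4 (0.38 log units; beyond the scatter)), which makes compound 4 the strongest inhibitor of the four. Adding ethyl at this chain does not have one fixed effect, since the outcome differs with the chain it is added to: the same change on two cores in this assay, a 1.5-fold higher number (0.18 log units; within the scatter) from compound 1 to compound 2 and a 2.4-fold lower number (0.37 log units; beyond the scatter) from compound 3 to compound 4, 3.6-fold (0.55 log units) apart, beyond the scatter of two such steps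
Adding propyl shows the same dependence on the starting chain: the same change on two cores in this assay, a 1.0-fold lower number (0.01 log units; within the scatter) from compound 1 to compound 3 and a 3.7-fold lower number (0.56 log units; beyond the scatter) from compound 2 to compound 4, 3.6-fold (0.55 log units) apart, beyond the scatter of two such steps

Only compound 4 stands apart from the others, so a single compound carries this gain. As far as these compounds go, whether a longer chain would lower the number further or raise it again stays open, as does the outcome of an amine or a carboxylic acid at the chain end.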